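The compounds below may be only part of what the source reports. "The series", "measured", "known", "first", "only" and "open" are said of these compounds alone.

Measured compounds:
compound 1 `COc1cc2ncnc(Nc3ccc(Cl)c(C(F)(F)F)c3)c2cc1OCCCCC(=O)Nc1ccc(S(N)(=O)=O)cc1`: 3220 nM
compound 2 `COc1cc2ncnc(Nc3cccc(Cl)c3F)c2cc1OCCCCC(=O)Nc1ccc(S(N)(=O)=O)cc1`: 6930 nM

Both were read in a functional assay on NCI-H1975 cells (Homo sapiens) for antiproliferative activity, read by MTT assay, with a stated time of 72 h; on this read-out lower numbers stand for stronger inhibition and higher numbers for weaker inhibition. For the measured compounds named here, compound 2 stands with the highest number of the two measured; the nearest and only neighbour is compound 1, a lower number, and the single step between measured compounds, a 2.2-fold higher number from compound 1 to compound 2 (0.33 log units; beyond the scatter), is the exchange of the aryl group on the nitrogen on an aromatic ring.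

Compound 3 `CCc1ccc(Nc2ncnc3cc(OC)c(OCCCCC(=O)Nc4ccc(S(N)(=O)=O)cc4)cc23)cc1` differs from compound 2 by 4-ethylphenyl in place of 3-chloro-2-fluorophenyl on a nitrogen on an aromatic ring. Going by the values given here, this is the same place that was varied in the one measured step, which moved the read-out modestly and beyond the scatter. Among the compounds with values here, no measured compound carries 4-ethylphenyl, so the direction of the change is not anchored; the one step at this position argues for a modest move at most. The expected step from compound 2 is a 1.1-fold higher number from compound 2 to compound 3 (0.03 log units; within the scatter), with a wide range. Compound 3 is estimated at 7500 nM, from 2500 nM to 22000 nM.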

Compound 3, half-maximal inhibitory concentration: 10300 nM
For compound 3 the middle estimate is 1.4-fold (0.14 log units) below the measured one; the range from low to high includes it.
By their numbers in this assay, from the lowest: compound 1; then compounds 2 and 3 (each within the scatter of the next).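

In this assay, the group on the nitrogen now includes 4-ethylphenyl, which has eight carbon atoms and no halogen. With a 1.5-fold higher number from compound 2 to compound 3 (0.17 log units; within the scatter), exchanging 3-chloro-2-fluorophenyl for this all-carbon group gives no separable change, so this one pair shows no dependence on the chlorine and fluorine atoms. By contrast, with a 3.2-fold higher number from compound 1 to compound 3 (0.50 log units; beyond the scatter), compound 1 stays apart from compound 3 as it does from compound 2, and 4-chloro-3-(trifluoromethyl)phenyl gives the lowest number of the three; nothing at hand bears on the reason for these steps.

The compounds shown leave open whether an amine or a carboxylic acid on this aryl ring would change the read-out. Also open, from the compounds shown here alone, is how a shorter or longer chain between the core and the amide would affect it.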